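The compounds below may be only part of what the source reports. "The series", "measured", "known", "first", "only" and "open" are said of these compounds alone.

Compound 3 `Cc1cc(N2CCCC2)c2ncc(CSCCc3ccccc3)n2c1` carries pyrrolidin-1-yl on the shared core. In an ADME assay on HEL cells (Homo sapiens) for cytotoxicity, with a stated time of 3 days (a lower number here means that less compound is tolerated, a higher number that more compound is tolerated), compound 3 gives only a limit, > 100 ug/mL, as the limit of > 100 ug/mL in this assay, at which 1 of the 3 values shown sits, records. For the measured compounds named here, compound 1 `Cc1cc(-c2ccc3[nH]ccc3c2)cn2c(CSCCc3ccccc3)cnc12` and compound 2 `Cc1cc(-n2ccc3ccccc32)cn2c(CSCCc3ccccc3)cnc12` carry an aromatic ring elsewhere on the core; in this assay compound 1 gives 26 ug/mL and compound 2 gives 18 ug/mL, and the single measured step, a 1.4-fold lower number from compound 1 to compound 2 (0.16 log units; within the scatter), lies within the scatter and does not concern the position altered here. Compound 4 `Cc1cc(Sc2ccc(O)cc2)c2ncc(CSCCc3ccccc3)n2c1` differs from compound 3 by (4-hydroxyphenyl)sulfanyl in place of pyrrolidin-1-yl on an aromatic carbon. Going by the values given here, no measured step bears directly on this exchange; compound 4, like compounds 1 and 2, now bears an aromatic ring. For compound 4 the step of an at least 1.8-fold lower number from compound 3 to compound 4 (0.25 log units; that floor lies within the scatter) is expected. Compound 4 is estimated at 55 ug/mL, within 20 ug/mL to 120 ug/mL.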

Compound 4, half-maximal cytotoxic concentration: 79 ug/mL
Estimate against measurement, compound 4: 1.4-fold (0.16 log units) below; low and high end bracket the measured number.
By their numbers in this assay, from the lowest: compounds 2 and 1 (each within the scatter of the next); then compound 4. At a limit, above all of these: compound 3.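

For the compounds shown here, at this position, on an aromatic carbon ortho to a fused ring, the exchange of pyrrolidin-1-yl for (4-hydroxyphenyl)sulfanyl gives the first reading in this assay: an at least 1.2-fold lower number from compound 3 to compound 4 (0.10 log units; that floor lies within the scatter). This floor does not establish a real fall in the tolerated concentration. Its true size stays unknown because compound 3 stands at a limit: the limit of > 100 ug/mL in this assay, at which 1 of the 4 values shown sits.

As far as these compounds go, whether the sulfur link, the aromatic ring or the hydroxyl group matters more remains open. So does the reading at this position for an open-chain amine such as diethylamino, or for a carboxylic acid.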